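Cytotoxicity notes: the difluorophenyl swap on compound 3

This account rests on a few compounds, and the source may have more. Where it says the series, first, only, none or still open, it means among the compounds named here.

In an ADME assay on MT4 cells (Homo sapiens) for cytotoxicity, read by MTT assay (a lower number here means that less compound is tolerated, a higher number that more compound is tolerated), compound 1 (`Cc1ccc(N(C(=O)c2ccccc2C)C(=S)OCCN2C(=O)c3ccccc3C2=O)cc1`) is reported only as a limit, > 100000 nM. Compound 2 (`Cc1ccc(N(C(=O)c2ccccc2[N+](=O)[O-])C(=S)OCCN2C(=O)c3ccccc3C2=O)cc1`) gives 100000 nM, and compound 3 (`Cc1ccc(N(C(=O)c2c(F)cccc2F)C(=S)OCCN2C(=O)c3ccccc3C2=O)cc1`) gives 65000 nM. Compound 3 cannot be separated from compound 2, the step being a 1.5-fold lower number from compound 2 to compound 3 (0.19 log units; within the scatter).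

Compound 4 (`Cc1ccc(N(C(=O)c2cc(F)cc(F)c2)C(=S)OCCN2C(=O)c3ccccc3C2=O)cc1`) carries 3,5-difluorophenyl in place of 2,6-difluorophenyl on a carbonyl carbon. The two have the same atoms, joined differently.

The nearest evidence is the set of changes on that same carbonyl carbon. These are a number no higher from compound 1 to compound 2 (the limit leaves the size open), an at least 1.5-fold lower number from compound 1 to compound 3 (0.18 log units; that floor lies within the scatter) and a 1.5-fold lower number from compound 2 to compound 3 (0.19 log units; within the scatter). None is shown to lie beyond the scatter, and no measured pair tests this particular swap. No clear direction follows, so no change beyond the scatter is expected in this assay. The expected step is a 1.2-fold higher number from compound 3 to compound 4 (0.09 log units; within the scatter). For compound 4 the estimated value is 80000 nM, with an expected range of 40000 nM to 130000 nM.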

Compound 4, half-maximal cytotoxic concentration: 54000 nM
Compound 4: middle estimate off by 1.5-fold (0.17 log units), on the high side, and the stated range covers the measured number.
By their numbers in this assay, from the lowest: compounds 4, 3 and 2 (each within the scatter of the next).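

In this assay, putting 3,5-difluorophenyl in place of 2,6-difluorophenyl on this carbonyl carbon, with the same atoms joined differently, gives a 1.2-fold lower number from compound 3 to compound 4 (0.08 log units; within the scatter), so this direct test of where the two fluorines sit shows no readable change. Against the 2-nitrophenyl compound the reading is a 1.9-fold lower number from compound 2 to compound 4 (0.27 log units; within the scatter), which leaves every fully readable step at this position inside the scatter. Compound 1 stands only as a limit, so an at least 1.8-fold lower number from compound 1 to compound 4 (0.26 log units; that floor lies within the scatter) is a floor and the true size of that step stays unread: the limit of > 100000 nM in this assay, at which 1 of the 4 values shown sits.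

As far as these compounds go, whether a cyclohexyl group or an aminomethylphenyl group on this carbonyl carbon would move the number beyond the scatter remains open. From the compounds shown here alone, the shared core is constant across these compounds, so the effect of a change elsewhere in it also remains open.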